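A few compounds are considered here, and "the series" means these few. Any claim that something is new, unique, unknown or untested is made for them only; others in the source may bear on it.

Among the compounds with values here, compound 2 `c1cn2cc(-c3ccsc3)nc(-c3ccc4ncn(C5CCCCC5)c4c3)c2n1` gives 29.2% in a functional assay on CCRF-CEM cells (Homo sapiens) for inhibition, read by sulforhodamine B assay, with a stated time of 48 h, tested at 10 uM (a higher number here means more inhibition at the concentration tested (going by the name of the read-out), a lower number less inhibition), the lower of the two numbers known so far, while compound 1 `O=Cc1ccc(-c2cn3ccnc3c(-c3ccc4ncn(C5CCCCC5)c4c3)n2)cc1` gives 77.9%. Within the data shown here, only one measured step exists, and it bears directly on the change at hand: a number 48.7 percentage points lower from compound 1 to compound 2 (beyond the scatter). Compound 3 `CC(=O)c1ccc(-c2cn3ccnc3c(-c3ccc4ncn(C5CCCCC5)c4c3)n2)cc1` differs from compound 2 on that same aromatic carbon: 4-acetylphenyl in place of thiophen-3-yl on an aromatic carbon. This change largely reverses the earlier one, since a carbon-only six-membered ring carrying a carbonyl returns in place of the five-membered sulfur ring, the carbonyl now being an acetyl rather than a formyl. Because a number 48.7 percentage points lower from compound 1 to compound 2 (beyond the scatter) was large and well beyond the scatter, a large rise in this assay is expected from compound 2 to compound 3, roughly recovering the level of compound 1. The expected step is a number 40.8 percentage points higher from compound 2 to compound 3 (beyond the scatter). Compound 3 is therefore estimated at about 70%, likely between 50% and 88%.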

Compound 3, a percentage reported as inhibition, at one concentration (the size of the read-out at that concentration, not a potency): 1.1%
Estimate against measurement, compound 3: 68.9 percentage points above, and the stated range ends above it.
By their numbers in this assay, from the lowest: compound 3; then compound 2; then compound 1.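

In this assay the carbonyl-bearing six-membered ring alone does not secure a high number: a methyl in place of hydrogen on the carbonyl carbon gives a large drop (a number 76.8 percentage points lower from compound 1 to compound 3 (beyond the scatter)). The thiophen-3-yl group, the poorer of the first two, now stands above 4-acetylphenyl (a number 28.1 percentage points lower from compound 2 to compound 3 (beyond the scatter)), so at this position the small difference between formyl and acetyl outweighs the change of the whole ring. Nothing available explains why so small an edit has so large an effect.

Going by these compounds, whether the high number depends on the formyl group itself remains open, and a hydroxymethyl, a carboxylic acid or an amine on the same phenyl ring would test this. A longer ketone chain in place of the acetyl could also show whether the fall continues with size.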